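Aromatic Furan Restores Potency Lost with a Saturated Ring

The source may report more compounds than this note shows. Statements on the series, on what has been measured and on what is new or still open speak of the compounds shown alone.

Measured compounds:
compound 1, `Cn1nc2c(=O)n(CC3(O)CCN(Cc4ccc(-c5ccco5)cc4Cl)CC3)cnc2c1-c1ccc(CNCCO)cc1`: 8.2 nM
compound 2, `Cn1nc2c(=O)n(CC3(O)CCN(Cc4ccc(C5CCCO5)cc4Cl)CC3)cnc2c1-c1ccc(CN)cc1`: 3820 nM
compound 3, `CCCNCc1ccc(-c2c3ncn(CC4(O)CCN(Cc5ccc(-c6ccco6)cc5Cl)CC4)c(=O)c3nn2C)cc1`: 43.9 nM

Compound 2 gives the highest number of the three in an assay on isolated protein for inhibition of ubiquitin carboxyl-terminal hydrolase 7 (Homo sapiens), with stated times of 30 min and 2 h; a higher number here means a weaker inhibitor, a lower number a stronger inhibitor. Going by the values given here, compounds 1 and 3 carry a furan-2-yl on the chlorinated ring, whereas compound 2 carries oxolan-2-yl, and compound 2 also differs from both in the amine on the other side of the shared core, so no single step links it to either. Among the compounds with values here, the one step that is known, a 5.4-fold higher number from compound 1 to compound 3 (0.73 log units; beyond the scatter), concerns only the amine substituent and does not touch the ring in question.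

Compound 4, `Cn1nc2c(=O)n(CC3(O)CCN(Cc4ccc(-c5ccoc5)cc4Cl)CC3)cnc2c1-c1ccc(CN)cc1`, differs from compound 2 in one place: furan-3-yl in place of oxolan-2-yl on an aromatic carbon. A five-membered aromatic ring thus replaces a five-membered non-aromatic ring, bringing compound 4 closer to the pattern of compounds 1 and 3, both of which give far lower numbers in this assay than compound 2.

Since compounds 1 and 3 share the aromatic five-membered ring with compound 4 but differ in the amine, the expected step of a 96-fold lower number from compound 2 to compound 4 (1.98 log units; beyond the scatter) is a large drop, though the primary amine of compound 4 leaves the size uncertain. Compound 4 is therefore estimated at 40 nM, with a range of 10 nM to 200 nM.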

Compound 4, half-maximal inhibitory concentration: 177 nM
Beside the measured number, compound 4's estimate is 4.4-fold (0.65 log units) below it; the range from low to high includes it.
By their numbers in this assay, from the lowest: compound 1; then compound 3; then compound 4; then compound 2.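

Read with the amine held fixed, the change at this position on the six-membered aromatic ring, meta to a chloro group and para to a large group, gives in this assay a step that is large and beyond the scatter (a 22-fold lower number from compound 2 to compound 4 (1.33 log units; beyond the scatter)), something the earlier compounds could not show, since compound 2 differed from compound 1 and compound 3 in two places. The leaving and entering groups match in every count given, with 5 heavy atoms, one five-membered ring with 1 hetero atom and the same hydrogen-bond tallies, so the step goes with the exchange of a non-aromatic ring for an aromatic one together with the shift of the ring's attachment point from its 2-position to its 3-position. The compounds shown give no measurement that explains the step.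

Those two changes travel together here, and oxolan-3-yl or furan-2-yl on the same primary amine scaffold would be needed to separate them. From the compounds shown here alone, compound 4 differs from compound 1 and compound 3 in two places, so those steps cannot be read, and whether a thiophene or phenyl ring would serve at this position also stays open.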